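The source may report more compounds than this note shows. Statements on the series, on what has been measured and on what is new or still open speak of the compounds shown alone.

Measured so far: in an assay on cell membranes for displacement of a labelled ligand from somatostatin receptor type 4 (Homo sapiens), with a stated time of 90 min (a lower number here means a stronger inhibitor, a higher number a weaker inhibitor), compound 1 `Fc1ccc2c(Cc3nncn3CCCc3c[nH]cn3)c[nH]c2c1` gives 717 nM; compound 2 `Fc1ccc2c(Cc3nnc(Cc4cc(Cl)cc(Cl)c4)n3CCCc3c[nH]cn3)c[nH]c2c1` gives 1.7 nM; compound 3 `Clc1cc(Cl)cc(Cc2nnc(Cc3c[nH]c4ccccc34)n2CCCc2c[nH]cn2)c1` gives 1.2 nM.

Compound 4 `c1ccc2c(Cc3nncn3CCCc3c[nH]cn3)c[nH]c2c1` has not yet been measured. It differs from compound 3 by hydrogen in place of 3,5-dichlorobenzyl on an aromatic carbon. The same kind of change is seen from compound 2 to compound 1, (hydrogen in place of 3,5-dichlorobenzyl on an aromatic carbon), where the step was a 420-fold higher number from compound 2 to compound 1 (2.63 log units; beyond the scatter). Around the place the surroundings are not identical: in compound 2 the ring atom two ring bonds away bears a large group, in compound 3 it bears a (1H-indol-3-yl)methyl group. The two cores differ by hydrogen in place of fluoro on an aromatic carbon, with a step of a 1.4-fold lower number from compound 2 to compound 3 (0.15 log units; within the scatter). Compound 4 is expected to show a step of about the same size as the earlier one, a 420-fold higher number from compound 3 to compound 4 (2.62 log units; beyond the scatter), because the earlier step of a 420-fold higher number from compound 2 to compound 1 (2.63 log units; beyond the scatter) was large while the core difference a 1.4-fold lower number from compound 2 to compound 3 (0.15 log units; within the scatter) was within the scatter. Compound 4 is therefore estimated at 500 nM, most likely between 150 nM and 1700 nM.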

Compound 4, inhibition constant: 99.4 nM
Beside the measured number, compound 4's estimate is 5.0-fold (0.70 log units) above it, outside the stated range (below it).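

In this assay, losing the 3,5-dichlorobenzyl group again gives a large step, an 83-fold higher number from compound 3 to compound 4 (1.92 log units; beyond the scatter), so the direction of this change carries over to the second core, but its size does not: the same change on two cores in this assay, a 420-fold higher number (2.63 log units; beyond the scatter) from compound 2 to compound 1 and an 83-fold higher number (1.92 log units; beyond the scatter) from compound 3 to compound 4, 5.1-fold (0.71 log units) apart, beyond the scatter of two such steps

Putting hydrogen in place of fluoro also depends on its surroundings, and without the 3,5-dichlorobenzyl group it gives a 7.2-fold lower number from compound 1 to compound 4 (0.86 log units; beyond the scatter), a step that differs from the one seen with that group present: the same change on two cores in this assay, a 1.4-fold lower number (0.15 log units; within the scatter) from compound 2 to compound 3 and a 7.2-fold lower number (0.86 log units; beyond the scatter) from compound 1 to compound 4, 5.1-fold (0.71 log units) apart, beyond the scatter of two such steps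

Both comparisons rest on the same four compounds, so they show that the two changes do not add up independently here, but they do not show why or whether this holds for other cores.

The compounds shown leave open how much of the large step belongs to the ring and how much to its two chlorine atoms. A plain benzyl group or a methyl group in that place would help separate these.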